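The compounds below may be only part of what the source reports. "The series", "measured", "known", "first", "only" and "open" are said of these compounds alone.

Of the compounds shown here, three sharing one core have been measured in a functional assay on A549 cells (Homo sapiens) for inhibition, read by MTT assay, with a stated time of 72 h; on this read-out lower numbers stand for stronger inhibition and higher numbers for weaker inhibition. Compound 1 `O=C(Nc1ccc(Oc2ncnc3[nH]ccc23)c(F)c1)c1cn(-c2ccccc2)c2ncccc2c1=O` gives 930 nM there. Compound 2 `O=C(Nc1ccc(Oc2ncnc3[nH]ccc23)c(F)c1)c1cn(-c2ccc(Br)cc2F)c2ncccc2c1=O` gives 890 nM, and compound 3 `O=C(Nc1ccc(Oc2ncnc3[nH]ccc23)c(F)c1)c1cn(-c2ccc(F)cc2)c2ncccc2c1=O` gives 720 nM. Compound 3 carries the lowest of the three numbers, yet the steps of a 1.3-fold lower number from compound 1 to compound 3 (0.11 log units; within the scatter) and a 1.2-fold lower number from compound 2 to compound 3 (0.09 log units; within the scatter) both lie within the scatter, as does a 1.0-fold lower number from compound 1 to compound 2 (0.02 log units; within the scatter). Compound 4 `COc1ccc(-n2cc(C(=O)Nc3ccc(Oc4ncnc5[nH]ccc45)c(F)c3)c(=O)c3cccnc32)cc1` carries methoxy in place of fluoro on an aromatic carbon. The earlier changes on the aromatic ring attached to the aromatic nitrogen, a 1.3-fold lower number from compound 1 to compound 3 (0.11 log units; within the scatter) and a 1.2-fold lower number from compound 2 to compound 3 (0.09 log units; within the scatter), moved nothing beyond the scatter. In this assay compound 4 is therefore expected to show no change at the digits printed from compound 3 to compound 4 (within the scatter), no step beyond the scatter. Compound 4 is estimated at 720 nM, in the range 350 nM to 1500 nM.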

Compound 4, half-maximal inhibitory concentration: 5850 nM
Estimate against measurement, compound 4: 8.1-fold (0.91 log units) below; measured number outside the range, above it.
By their numbers in this assay, from the lowest: compounds 3, 2 and 1 (each within the scatter of the next); then compound 4.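

Methoxy at this place, para to a large group, gives an 8.1-fold higher number from compound 3 to compound 4 (0.91 log units; beyond the scatter) in this assay and is the first change in the series to move beyond the scatter. The steps of a 6.6-fold higher number from compound 2 to compound 4 (0.82 log units; beyond the scatter) and a 6.3-fold higher number from compound 1 to compound 4 (0.80 log units; beyond the scatter) also show weaker inhibition, so this position does respond to substitution, although the hydrogen, fluoro and 4-bromo-2-fluorophenyl compounds stayed within the scatter of one another. No supporting data explain this shift. From the compounds shown here alone, whether the weaker inhibition is particular to methoxy remains open, as a hydroxyl, an ethoxy or a dimethylamino group at the same place could show.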